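Sulfur for oxygen at the carbonyl of compound 3

The source may report more compounds than this note shows. Statements on the series, on what has been measured and on what is new or still open speak of the compounds shown alone.

Compound 3 `CCC1(OC(=O)N2CCC(Oc3ncnc(Oc4ccc(S(C)(=O)=O)nc4C)c3F)CC2)CC1` gives 22 nM in a functional assay on isolated protein for inhibition of Glucose-dependent insulinotropic receptor (Homo sapiens), read by HTRF and cAMP accumulation; on this read-out higher numbers stand for an effect only at larger amounts of compound and lower numbers for an effect already at smaller amounts. Among the three numbers known it stands second highest: compound 1 `Cc1nc(S(C)(=O)=O)ccc1Oc1ncnc(OC2CCN(C(=O)OC3CCC3)CC2)c1F` gives 13.6 nM, with a 1.6-fold higher number from compound 1 to compound 3 (0.21 log units; within the scatter), while compound 2 `Cc1nc(S(C)(=O)=O)ccc1Oc1ncnc(OC2CCN(C(=O)O[C@@H](C)CF)CC2)c1F` gives 186 nM, with an 8.5-fold lower number from compound 2 to compound 3 (0.93 log units; beyond the scatter).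

Compound 4 `Cc1nc(S(C)(=O)=O)ccc1Oc1ncnc(OC2CCN(C(=O)SC(C)C)CC2)c1F` differs from compound 3 by a group of 4 heavy atoms (3 carbon, 1 sulfur; no ring) in place of a group of 6 heavy atoms (5 carbon, 1 oxygen; one three-membered non-aromatic ring of carbon only), on a carbonyl carbon. Every measured step in this assay changes only the group on the oxygen next to the carbonyl group, and the oxygen is kept. Of these, a 14-fold higher number from compound 1 to compound 2 (1.14 log units; beyond the scatter) shows that an open-chain group in place of a ring costs much, whereas ring for ring is within the scatter. Among the compounds with values here, compound 4 again carries an open-chain group, but in addition the oxygen itself is exchanged for sulfur, and no measured step covers that exchange. Taking the open-chain step as the nearest guide, a rise beyond the scatter is expected, smaller than from compound 1 to compound 2: the expected step is a 2.7-fold higher number from compound 3 to compound 4 (0.44 log units; beyond the scatter). Compound 4 is thus estimated at 60 nM, in a range from 20 nM to 200 nM.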

Compound 4, half-maximal effective concentration: 6.8 nM
For compound 4 the middle estimate is 8.8-fold (0.95 log units) above the measured one, and the stated range ends above it.
By their numbers in this assay, from the lowest: compounds 4, 1 and 3 (each within the scatter of the next, the first and the last beyond it); then compound 2.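

The open-chain isopropylsulfanyl group on the carbonyl carbon does not repeat the rise seen with the open-chain 1-(fluoromethyl)ethyl group: in this assay there is a 27-fold lower number from compound 2 to compound 4 (1.44 log units; beyond the scatter), and also a 3.2-fold lower number from compound 3 to compound 4 (0.51 log units; beyond the scatter). Against cyclobutyloxy the exchange stays within the scatter, with a 2.0-fold lower number from compound 1 to compound 4 (0.30 log units; within the scatter), so among these compounds a ring on this carbonyl carbon is not required for a number at the low end of the set. The compounds shown thus separate two open-chain groups by a large step, which the earlier ring-for-ring and ring-to-chain steps could not show. Nothing at hand gives a reason for these steps.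

Open, from the compounds shown here alone, is whether the sulfur or the isopropyl part carries the step, which an isopropyloxy group on the same carbonyl carbon would separate. Also open, going by these compounds, is how a cyclobutylsulfanyl group or an isopropylamino group would read here.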